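The source may hold more compounds than are shown below. What is called first, only, known or untested is meant among the compounds shown, and "the series" means these compounds.

In an assay on cells for inhibition of Indoleamine 2,3-dioxygenase 1 (Homo sapiens), read by HPLC, with a stated time of 20 min (a lower number here means a stronger inhibitor, a higher number a weaker inhibitor), compound 3 `Oc1ccc(Cl)cc1-c1nnc[nH]1` gives 600 nM, the lowest of the three numbers measured. Its nearest neighbour is compound 2 `Nc1ccccc1-c1nnc[nH]1`, which in this assay gives 2000 nM; the furthest is compound 1 `Clc1cccc(-c2nnc[nH]2)c1`, which gives 31000 nM. Compound 4 `Nc1ccc(Cl)cc1-c1nnc[nH]1` differs from compound 3 by amino in place of hydroxy on an aromatic carbon. Within the data shown here, no measured step swaps these two groups directly. The only single-place step shown is a 52-fold lower number from compound 1 to compound 3 (1.71 log units; beyond the scatter), which tells how much the hydroxy group contributes, and compound 2 shows that an amino group without the chloro group reaches a middling number. Compound 4 is therefore expected to give a somewhat higher number than compound 3, a step of a 2.5-fold higher number from compound 3 to compound 4 (0.40 log units; beyond the scatter). Compound 4 is estimated at 1500 nM, with a range from 400 nM to 6000 nM.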

Compound 4, half-maximal inhibitory concentration: 35 nM
Beside the measured number, compound 4's estimate is 43-fold (1.63 log units) above it; measured number outside the range, below it.
By their numbers in this assay, from the lowest: compound 4; then compound 3; then compound 2; then compound 1.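

In this assay, among these compounds, amino in place of hydroxy, at the position para to a chloro group, gives a 17-fold lower number from compound 3 to compound 4 (1.23 log units; beyond the scatter) and so separates two groups that no earlier step had compared directly. The chloro group also counts when the amino group is present, with a 57-fold lower number from compound 2 to compound 4 (1.76 log units; beyond the scatter) as the step for adding it, while an 890-fold lower number from compound 1 to compound 4 (2.95 log units; beyond the scatter) is the step for adding the amino group to the chloro compound. No evidence on why these steps are so large is available. Going by these compounds, whether a methylamino group or an acetamide at this position keeps the low number remains open, as does whether bromo or fluoro can replace the chloro group.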